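The source may hold more compounds than are shown below. What is called first, only, known or untested is meant among the compounds shown, and "the series" means these compounds.

Measured in a functional assay on SK-BR-3 cells (Homo sapiens) for antiproliferative activity; a lower number here means a stronger inhibitor, a higher number a weaker inhibitor:
Compound 1 `CCCCOc1ccc(C(=O)Nc2cc3ccc(OC4CCN(C)CC4)c(C)c3oc2=O)cc1CC=C(C)C`: 1400 nM
Compound 2 `CC(=O)Oc1ccc(C(=O)Nc2cc3ccc(OC4CCN(C)CC4)c(C)c3oc2=O)cc1`: 1670 nM
Compound 3 `CC(C)=CCc1cccc(C(=O)Nc2cc3ccc(OC4CCN(C)CC4)c(C)c3oc2=O)c1`: 1680 nM

Compound 3, at 1680 nM, stands level with the other two compounds, since its steps to both lie within the scatter. Compound 4 `Cc1c(OC2CCN(C)CC2)ccc2cc(NC(=O)c3ccccc3)c(=O)oc12` takes compound 3 and puts hydrogen in place of 3-methylbut-2-en-1-yl on an aromatic carbon, leaving a plain phenyl: hydrogen in place of 3-methylbut-2-en-1-yl on an aromatic carbon.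

Within the data shown here, no measured step removes this group directly, so the evidence is indirect. Loss of the butoxy group gives a 1.2-fold higher number from compound 1 to compound 3 (0.08 log units; within the scatter). Compound 2 has no 3-methylbut-2-en-1-yl group, and exchanging its 4-acetoxyphenyl gives a 1.0-fold higher number from compound 2 to compound 3 (0.00 log units; within the scatter). Both steps are within the scatter, so no change beyond the scatter is expected in this assay, in either direction, although the untested removal leaves the range wide. The expected step is a 1.2-fold higher number from compound 3 to compound 4 (0.08 log units; within the scatter). The estimate for compound 4 is 2000 nM, with an expected range from 900 nM to 4500 nM.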

Compound 4, half-maximal inhibitory concentration: 11500 nM
Beside the measured number, compound 4's estimate is 5.8-fold (0.76 log units) below it, and the stated range ends below it.
By their numbers in this assay, from the lowest: compounds 1, 2 and 3 (each within the scatter of the next); then compound 4.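

In this assay, compound 4 is the only compound shown with a plain phenyl, and it shows that this ring does not tolerate losing its substituent: the earlier compounds all carried one and could not reveal this. Taking away 3-methylbut-2-en-1-yl gives (a 6.8-fold higher number from compound 3 to compound 4 (0.84 log units; beyond the scatter)), and taking away acetoxy gives (a 6.9-fold higher number from compound 2 to compound 4 (0.84 log units; beyond the scatter)), so two quite different groups each stand apart from hydrogen by a step beyond the scatter. No measurement here gives a reason for this.

As far as these compounds go, it remains open whether a much shorter group, such as methoxy, would keep the number level with compound 3 at 1680 nM. From the compounds shown here alone, an amine or a carboxylic acid on this ring is equally open, as is whether any group at all would serve there.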